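Ring Size at the Chain End: From Compound 2 to Compound 3

A few compounds are considered here, and "the series" means these few. Any claim that something is new, unique, unknown or untested is made for them only; others in the source may bear on it.

Compound 1 `COc1cc2c(Nc3nc4ccc(C(=O)Nc5c(C)cccc5C)cc4s3)ncnc2cc1OCCCN1CCCCC1`: 14700 nM
Compound 2 `COc1cc2c(Nc3nc4ccc(C(=O)Nc5c(C)cc(C)cc5C)cc4s3)ncnc2cc1OCCCN1CCCCC1`: 12200 nM

In a functional assay on U-937 cells (Homo sapiens) for cytotoxicity, read by WST assay, with a stated time of 72 h (on this read-out higher numbers stand for weaker inhibition and lower numbers for stronger inhibition), compound 1 gives 14700 nM and compound 2 gives 12200 nM. Compound 2 stands at the lower of the two numbers, yet the step of a 1.2-fold lower number from compound 1 to compound 2 (0.08 log units; within the scatter) is within the scatter, so the two are not separated. Compound 3 `COc1cc2c(Nc3nc4ccc(C(=O)Nc5c(C)cc(C)cc5C)cc4s3)ncnc2cc1OCCCN1CCCC1` differs from compound 2 by pyrrolidin-1-yl in place of piperidin-1-yl on a saturated chain carbon, three bonds along the chain from an oxygen on an aromatic ring. Within the data shown here, no measured step touches this part of the molecule; the only measured step, a 1.2-fold lower number from compound 1 to compound 2 (0.08 log units; within the scatter), concerns the aromatic methyl, so nothing beyond the scatter is expected in this assay. Compound 3 is therefore estimated at 12000 nM, within 5000 nM to 30000 nM, a step of a 1.0-fold lower number from compound 2 to compound 3 (0.01 log units; within the scatter).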

Compound 3, half-maximal inhibitory concentration: 4600 nM
For compound 3 the middle estimate is 2.6-fold (0.42 log units) above the measured one; the measured number lies below the stated range.
By their numbers in this assay, from the lowest: compound 3; then compounds 2 and 1 (each within the scatter of the next).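

In this assay, pyrrolidin-1-yl in place of piperidin-1-yl gives a 2.7-fold lower number from compound 2 to compound 3 (0.42 log units; beyond the scatter), a modest step but the only one here beyond the scatter. The chain end therefore responds to going from a six-membered to a five-membered ring, which the aromatic methyl step could not show. Nothing available explains this step. The compounds shown leave open how a morpholine ring, a dimethylamino group or a 2-(pyrrolidin-1-yl)ethyl chain would read at this place. They also leave open whether the step carries over to the core of compound 1.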